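Cytotoxicity limits across four analogues sharing one core

The source may report more compounds than this note shows. Statements on the series, on what has been measured and on what is new or still open speak of the compounds shown alone.

Compound 1 `Nc1nc(NCc2ccccc2)c2ncn(/C=C3/CC3(CO)CO)c2n1` is assessed in an ADME assay on CCRF-HSB-2 cells (Homo sapiens) for cytotoxicity, with a stated time of 7 days; a lower number here means that less compound is tolerated, a higher number that more compound is tolerated. There compound 1 gives > 20000 nM, which is a limit of the assay rather than a number. Compound 2 `Nc1nc2c(ncn2/C=C2/CC2(CO)CO)c(=O)[nH]1` likewise gives > 20000 nM in this assay, again only a limit. Compound 3 `CCCNc1nc(N)nc2c1ncn2/C=C1/CC1(CO)CO` gives > 20000 nM in this assay, also a limit. Among the measured compounds shown here, the single step between measured compounds, a step that the two limits leave unreadable from compound 1 to compound 3, is unreadable, both of its ends being limits. Compound 4 `CC(C)Sc1nc(N)nc2c1ncn2/C=C1/CC1(CO)CO` differs from compound 1 as follows: isopropylsulfanyl in place of benzylamino on an aromatic carbon. For the measured compounds named here, no measured step can be read against this change; the only evidence is the limit of > 20000 nM in this assay, at which 3 of the 3 values shown sit. Compound 4 is therefore expected to stay at the limit in this assay, with an estimate of 30000 nM (range 10000 nM to 100000 nM), the expected step that the limit leaves unreadable from compound 1 to compound 4 itself remaining unreadable.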

Compound 4, half-maximal cytotoxic concentration: 94000 nM
Beside the measured number, compound 4's estimate is 3.1-fold (0.50 log units) below it, and the stated range covers the measured number.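

Among the compounds shown here, no step to compound 4 can be read from compound 1 or compound 3 in this assay, since both of those compounds give only a limit: the limit of > 20000 nM in this assay, at which 3 of the 4 values shown sit.

Going by these compounds, whether isopropylsulfanyl truly changes tolerance relative to benzylamino or propylamino remains open.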